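Working notes: compound 3 against compound 2

The source may report more compounds than this note shows. Statements on the series, on what has been measured and on what is new or still open speak of the compounds shown alone.

Measured so far:
Compound 1 `COc1ccc2c(c1)CCc1ccc(OC)c(c1)Oc1ccc(cc1)C(O)C(Br)c1cccc(c1)O2` — in a functional assay on KB cells (Homo sapiens) for cytotoxicity, read by MTT assay, with a stated time of 48 h, tested at 10 uM (on this read-out higher numbers stand for more inhibition at the one concentration tested (going by the name of the read-out) and lower numbers for less inhibition), compound 1 gives 2.82%.
Compound 2 `COc1ccc2c(c1)CCc1ccc(OC)c(c1)Oc1ccc(cc1)-c1nc(N)sc1-c1cccc(c1)O2` — in this assay compound 2 gives 0%.

Both measured compounds sit close to zero inhibition. The difference between compound 2 and compound 1 lies within the scatter of this kind of measurement, so compound 2 is not set apart from compound 1 on the numbers shown; the two read as one level. Within the data shown here, no comparison between the two measured compounds can be cut to a single structural place, so no step is known for the series yet.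

Compound 3 `COc1ccc2c(c1)CCc1ccc(OC)c(c1)Oc1ccc(cc1)-c1nc(NN)sc1-c1cccc(c1)O2` is the next member to be tested. It differs from compound 2 in one place: amino in place of hydrogen on a nitrogen on an aromatic ring.

Among the measured compounds shown here, with only near-zero values in hand, there is no measured step on which to build a direction. The expected step from compound 2 to compound 3 in this assay is a number 3 percentage points higher from compound 2 to compound 3 (within the scatter), which is no change beyond the scatter. Compound 3 is estimated at 3%, with a range from 0% to 15%.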

Compound 3, a percentage reported as inhibition, at one concentration (the size of the read-out at that concentration, not a potency): 0%
Estimate against measurement, compound 3: 3 percentage points above; measured number inside the range.
By their numbers in this assay, from the lowest: compounds 2, 3 and 1 (each within the scatter of the next).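

In this assay, among these compounds, amino in place of hydrogen on a nitrogen on an aromatic ring gives the first one-place step (no change at the digits printed from compound 2 to compound 3 (within the scatter)), so this position now has a measured change, one that adds a single nitrogen as heavy atom, with one hydrogen-bond donor, one hydrogen-bond acceptor and no net charge. Among the compounds shown here, compound 2 already stands at 0%, so the step starts from a level with no inhibition to lose and shows only that this particular change does not raise the read-out beyond the scatter, not that the position is indifferent to what it carries. No measurement is available that would explain this result.

Whether an acetyl group, a longer chain such as aminoethyl, or a chain ending in a carboxylic acid on this same nitrogen would lift inhibition out of the level shared by the compounds shown remains open. Also open, as far as these compounds go, is whether amino in place of hydrogen at this position would have any effect on a member of the series with clear inhibition in this assay, since a step measured from such a low level cannot settle that.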